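This account rests on a few compounds, and the source may have more. Where it says the series, first, only, none or still open, it means among the compounds named here.

Measured in an ADME assay on HepG2 cells (Homo sapiens) for cytotoxicity, read by MTT assay, with a stated time of 72 h; on this read-out lower numbers stand for higher toxicity in this test and higher numbers for lower toxicity in this test:
- Compound 1 `COc1ccc(C#Cc2cc(Cl)cn3c([N+](=O)[O-])c(CS(=O)(=O)c4ccccc4)nc23)cc1`: > 3900 nM (a limit)
- Compound 2 `O=[N+]([O-])c1c(CS(=O)(=O)c2ccccc2)nc2c(C#Cc3cccc(F)c3)cc(Cl)cn12`: > 3900 nM (a limit)
- Compound 3 `CC(O)(C#Cc1cc(Cl)cn2c([N+](=O)[O-])c(CS(=O)(=O)c3ccccc3)nc12)c1ccccc1`: 18800 nM

Compound 2 has no exact number, only the limit > 3900 nM. This is the limit of > 3900 nM in this assay, at which 2 of the 3 values shown sit. Compound 4 `O=[N+]([O-])c1c(CS(=O)(=O)c2ccccc2)nc2c(C#CCO)cc(Cl)cn12` carries hydroxymethyl in place of 3-fluorophenyl on a triple-bonded carbon. The steps bearing on this are a step that the limit leaves unreadable from compound 2 to compound 3 and a step that the limit leaves unreadable from compound 1 to compound 3, so no measured size carries over. Only compound 3, with 1-hydroxy-1-phenylethyl on that triple-bonded carbon, gives a number, 18800 nM. On that single value, the expected change is a step that the limit leaves unreadable from compound 2 to compound 4, towards lower toxicity in this assay, though this is uncertain. For compound 4 the estimated value is 15000 nM, with an expected range of 4500 nM to 50000 nM.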

Compound 4, half-maximal cytotoxic concentration: 10100 nM
Beside the measured number, compound 4's estimate is 1.5-fold (0.17 log units) above it; measured number inside the range.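

On a triple-bonded carbon in this assay, the step between the two groups with exact values is a 1.9-fold lower number from compound 3 to compound 4 (0.27 log units; within the scatter). Hydroxymethyl, which has no ring, therefore gives a value within the usual scatter of the one for 1-hydroxy-1-phenylethyl. The steps from compound 1 and compound 2 cannot be read, because both compounds carry only a limit: the limit of > 3900 nM in this assay, at which 2 of the 4 values shown sit.

On these data alone, whether 3-fluorophenyl or 4-methoxyphenyl on this carbon truly differs from these two hydroxyl-bearing groups remains open. Also open, as far as these compounds go, is what an amine or a carboxylic acid would give there.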